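A few compounds are considered here, and "the series" means these few. Any claim that something is new, unique, unknown or untested is made for them only; others in the source may bear on it.

Measured compounds:
- compound 1 `Cn1c(-c2cccc(Cl)c2)nc2c(NC3CCCC3)ncnc21`: 514 nM
- compound 2 `CCn1c(-c2ccccc2)nc2c(NC3CCOC3)ncnc21`: 1660 nM

Of these two, compound 1 gives the lowest number in an assay on CHO cells for displacement of a labelled ligand from adenosine receptor A3 (Homo sapiens), read by scintillation counting, with a stated time of 3 h (on this read-out higher numbers stand for weaker inhibition and lower numbers for stronger inhibition), at 514 nM, which places it as the stronger binder of the pair. Compound 2 gives 1660 nM in this assay, and the gap between the two values lies beyond the usual scatter of repeated measurements.

Compound 3 `Cn1c(-c2cccnc2)nc2c(NC3CCCC3)ncnc21` has not yet been measured. It differs from compound 1 in one place: pyridin-3-yl in place of 3-chlorophenyl on an aromatic carbon. Among the compounds with values here, no measured pair in the set shows this particular exchange, so its effect cannot be read from a recorded step. On the numbers shown, a moderate weakening is expected, of a size that may only just exceed the scatter, giving the step of a 2.3-fold higher number from compound 1 to compound 3 (0.37 log units; beyond the scatter). For compound 3 the estimate in this assay is 1200 nM, with a range from 400 nM to 4000 nM.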

Compound 3, inhibition constant: 11000 nM
For compound 3 the middle estimate is 9.2-fold (0.96 log units) below the measured one; measured number above the stated range.
By their numbers in this assay, from the lowest: compound 1; then compound 2; then compound 3.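

Placing pyridin-3-yl in place of 3-chlorophenyl, on the aromatic carbon between two ring nitrogen atoms, gives in this assay a 21-fold higher number from compound 1 to compound 3 (1.33 log units; beyond the scatter), a large step beyond the scatter. Within the data shown here, this is the first step recorded at this position, and it shows that the number in this assay depends strongly on the group held there, even though the rest of compound 1 stays unchanged. No supporting data show whether the step follows from the loss of the chlorine or from the arrival of the ring nitrogen.

The compounds shown leave open how the step divides between those two parts, which a plain phenyl on the core of compound 1 would help to separate. Also open, on these data alone, is whether 3-fluorophenyl or 3-methoxyphenyl at this place would give a number nearer that of compound 1 or that of compound 3.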